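This account rests on a few compounds, and the source may have more. Where it says the series, first, only, none or still open, it means among the compounds named here.

Working notes on the shared core of compound 1 `CC(=O)NCc1cccc(Cn2nc(NS(=O)(=O)c3ccc(Cl)s3)c3ccccc32)c1`, tested in a functional assay on CHO cells for antagonist activity at C-C chemokine receptor type 4 (Homo sapiens), read by GTPgammaS binding; a lower number here means a stronger inhibitor, a higher number a weaker inhibitor. Compound 1 gives 251 nM. Compound 2 `CC(=O)NCc1cccc(Cn2nc(NS(=O)(=O)c3ccc(Cl)s3)c3c(F)cccc32)c1` gives 79.4 nM, the step being a 3.2-fold lower number from compound 1 to compound 2 (0.50 log units; beyond the scatter). Compound 3 `CC(=O)NCc1cccc(Cn2nc(NS(=O)(=O)c3ccc(Cl)s3)c3c(O)cccc32)c1` gives 12.6 nM, the lowest number of the three; the steps to it are a 20-fold lower number from compound 1 to compound 3 (1.30 log units; beyond the scatter) and a 6.3-fold lower number from compound 2 to compound 3 (0.80 log units; beyond the scatter). Compound 4 `CC(=O)NCc1cccc(Cn2nc(NS(=O)(=O)c3ccc(Cl)s3)c3c(CO)cccc32)c1` carries hydroxymethyl in place of hydroxy on an aromatic carbon. Among the measured compounds shown here, no measured step exchanges hydroxy for hydroxymethyl; the only step that bears on the change is the large gain a 20-fold lower number from compound 1 to compound 3 (1.30 log units; beyond the scatter) from adding the hydroxy, and nothing shows how much of it survives the change. A modest rise is therefore expected, a 3.2-fold higher number from compound 3 to compound 4 (0.50 log units; beyond the scatter). Compound 4 is estimated at 40 nM in this assay, range 10 nM to 160 nM.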

Compound 4, half-maximal inhibitory concentration: 6.31 nM
The estimate for compound 4 lay 6.3-fold (0.80 log units) above the measured number; measured number outside the range, below it.
By their numbers in this assay, from the lowest: compounds 4 and 3 (each within the scatter of the next); then compound 2; then compound 1.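

In this assay, the gain seen with hydroxy at this aromatic carbon survives the exchange for hydroxymethyl: a 2.0-fold lower number from compound 3 to compound 4 (0.30 log units; within the scatter) leaves the two groups indistinguishable. The distance from the other groups holds, with a 13-fold lower number from compound 2 to compound 4 (1.10 log units; beyond the scatter) and a 40-fold lower number from compound 1 to compound 4 (1.60 log units; beyond the scatter), so this position tolerates the larger hydroxymethyl group without measurable loss. No evidence at hand bears on why the two groups match. Still open, as far as these compounds go, is whether the hydroxyl hydrogen matters, which a methoxymethyl group could test. Also open, from the compounds shown here alone, is whether an aminomethyl group, a carboxylic acid or a longer hydroxyethyl chain at this carbon keeps the number.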